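The source may report more compounds than this note shows. Statements on the series, on what has been measured and on what is new or still open speak of the compounds shown alone.

Working notes on a set of three measured analogues sharing one core, all read in a functional assay on MDA-MB-231 cells (Homo sapiens) for cytotoxicity, read by MTT assay, with a stated time of 48 h; a higher number here means a weaker inhibitor, a lower number a stronger inhibitor. Compound 1 is `O=C(/C=C\Nc1ccc(F)cc1)c1nc(-c2ccc(C(F)(F)F)cc2)n2ccccc12`. Compound 2 is `O=C(/C=C\Nc1cnc2ccccc2c1)c1nc(-c2ccc(C(F)(F)F)cc2)n2ccccc12`. Compound 3 is `O=C(/C=C\Nc1ccc2cc[nH]c2c1)c1nc(-c2ccc(C(F)(F)F)cc2)n2ccccc12`. In this assay compound 1 gives > 30000 nM, which is a limit of the assay and not a number. In this assay compound 2 also reaches only a limit, > 30000 nM. In this assay compound 3 likewise stops at a limit, > 30000 nM. The three measured steps, a step that the two limits leave unreadable from compound 1 to compound 2, a step that the two limits leave unreadable from compound 1 to compound 3 and a step that the two limits leave unreadable from compound 2 to compound 3, all exchange the aryl on the amine nitrogen, and none has a readable size because of the limit of > 30000 nM in this assay, at which 3 of the 3 values shown sit. Compound 2 therefore stands at the limit, with the two other values shown sitting at the same limit.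

The next compound, compound 4, is `O=C(/C=C\Nc1cnc2ccccc2c1)c1nc(-c2ccccc2)n2ccccc12`. It differs from compound 2 in hydrogen in place of trifluoromethyl on an aromatic carbon; the change sits on an aromatic carbon of a six-membered aromatic ring of carbon only, and cut one bond further out it reads 4-(trifluoromethyl)phenyl to phenyl. For the measured compounds named here, no measured step touches this part of the molecule, so none bears directly on it; the steps at the amine nitrogen left every value at the limit. The expected step is a step that the limit leaves unreadable from compound 2 to compound 4, most likely unreadable against that limit. Compound 4 is estimated at 35000 nM, within 8000 nM to 150000 nM.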

Compound 4, half-maximal inhibitory concentration: 12300 nM
Estimate against measurement, compound 4: 2.8-fold (0.45 log units) above; measured number inside the range.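

Taking the trifluoromethyl off the 4-(trifluoromethyl)phenyl group gives an at least 2.4-fold lower number from compound 2 to compound 4 (0.38 log units; beyond the scatter) in this assay, and this is the first change in the set with a direction that can be read. It shows that this position, on an aromatic carbon of a six-membered aromatic ring of carbon only and para to a large group, can move the number, whereas the exchanges of aryl on the amine nitrogen cannot be read at all. The true size of the new step remains unknown, and it stands only as a minimum because its starting point is a limit of the assay and not a number: the limit of > 30000 nM in this assay, at which 3 of the 4 values shown sit.

On these data alone, it remains open whether the gain follows from hydrogen in particular or whether other groups on the same carbon, such as a chlorine, a methoxy or an amine, would read the same way. Also open, as far as these compounds go, is whether, with phenyl in place of 4-(trifluoromethyl)phenyl, the aryl on the amine nitrogen now matters, for instance 4-fluorophenyl or 1H-indol-6-yl against the quinolin-3-yl of compound 4.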